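Ethyl to phenyl on the ether oxygen of compound 1

A few compounds are considered here, and "the series" means these few. Any claim that something is new, unique, unknown or untested is made for them only; others in the source may bear on it.

Compound 1 `CCOCCn1c(N2CCN(C)CC2)nc2ccccc21` gives 10 nM in a functional assay on ileum for inhibition of histamine H1 receptor (Cavia porcellus) (a higher number here means a weaker inhibitor, a lower number a stronger inhibitor), the lowest of the two numbers shown. For the measured compounds named here, compound 2 `CCCSCn1c(N2CCN(C)CC2)nc2ccccc21` gives 68 nM in this assay, and the step of a 6.8-fold higher number from compound 1 to compound 2 (0.83 log units; beyond the scatter) is the only measured change at the chain on the saturated carbon bound to the aromatic nitrogen. Compound 3 `CCOCCn1c(N2CCN(C(c3ccccc3)c3ccccc3)CC2)nc2ccccc21` reaches only a limit in this assay, > 3000 nM, namely (the limit of > 3000 nM in this assay, at which 1 of the 3 values shown sits); its change lies elsewhere and tells nothing about this chain. Compound 4 `CN1CCN(c2nc3ccccc3n2CCOc2ccccc2)CC1` carries phenyl in place of ethyl on an oxygen on a saturated carbon. Going by the values given here, the one relevant step was modest, so a modest step is expected here too, most likely toward a higher number. For compound 4 a value of 30 nM is estimated, within 8 nM to 120 nM. The expected step is a 3.0-fold higher number from compound 1 to compound 4 (0.48 log units; beyond the scatter).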

Compound 4, half-maximal inhibitory concentration: 6.9 nM
The estimate for compound 4 lay 4.3-fold (0.64 log units) above the measured number; measured number below the stated range.
By their numbers in this assay, from the lowest: compounds 4 and 1 (each within the scatter of the next); then compound 2. At a limit, above all of these: compound 3.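

In this assay, for the compounds shown here, phenyl in place of ethyl on the oxygen is tolerated, with a 1.4-fold lower number from compound 1 to compound 4 (0.16 log units; within the scatter); the earlier compounds held no aromatic ring at this position. Phenoxymethyl in place of propylsulfanyl, by contrast, gives a step beyond the scatter, with a 9.9-fold lower number from compound 2 to compound 4 (0.99 log units; beyond the scatter). Nothing measured here offers a reason for either step. Still open, going by these compounds, is whether a phenyl ring carrying a carboxylic acid or an amine is tolerated on this oxygen. On these data alone, a longer chain on the aromatic nitrogen also remains open.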